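Replacing the 4-acetylphenyl group of an inactive compound

The source may hold more compounds than are shown below. What is called first, only, known or untested is meant among the compounds shown, and "the series" means these compounds.

In a functional assay on HL-60 cells (Homo sapiens) for inhibition, read by MTT assay, with a stated time of 72 h (a higher number here means a weaker inhibitor, a lower number a stronger inhibitor), compound 3 (`CC(=O)c1ccc(N2CCN(C(=O)c3oc(C)nc3-c3ccccc3)CC2)cc1`) has no number: it is recorded as "not active" (no number reported) and so offers no measured starting point. Compound 1 (`Cc1nc(-c2ccccc2)c(C(=O)N2CCN(c3cccc(Cl)c3Cl)CC2)o1`) gives 133 nM in this assay on the same core. Compound 2 (`Cc1nc(-c2ccccc2)c(C(=O)N2CCN(c3cccc(C)c3C)CC2)o1`) gives 35 nM in this assay on that core as well.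

Compound 4 (`Cc1ccc(N2CCN(C(=O)c3oc(C)nc3-c3ccccc3)CC2)c(C)c1`) differs from compound 3 in one place, with 2,4-dimethylphenyl in place of 4-acetylphenyl on an amine nitrogen in a ring. Among the measured compounds shown here, the only measured step at that nitrogen is a 3.8-fold lower number from compound 1 to compound 2 (0.58 log units; beyond the scatter) with 2,3-dimethylphenyl in place of 2,3-dichlorophenyl, and it is modest but beyond the scatter. That step does not involve compound 3, so it cannot set the size of the change, and no size can be stated from a result without a number.

The expected direction is still towards a measurable value. This rests on compound 2 at 35 nM as the nearest relative, although its two methyl groups sit differently and the data do not show what that does. A repeat of the inactive result remains possible. For compound 4 the estimated value is 90 nM with an expected range of 20 nM to 500 nM in this assay if a number is obtained at all.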

Compound 4, half-maximal inhibitory concentration: 101 nM
For compound 4 the middle estimate is 1.1-fold (0.05 log units) below the measured one; the measured number falls inside the stated range.
By their numbers in this assay, from the lowest: compound 2; then compounds 4 and 1 (each within the scatter of the next).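

In this assay, compound 4 shows that a number can be obtained with 2,4-dimethylphenyl on this ring nitrogen, where the 4-acetylphenyl of compound 3 gave none, although the missing number means that this change has no readable size. The earlier compounds shown here showed only a swap of chlorine for methyl at fixed positions, whereas the new result shows that the placement of the two methyl groups also counts, with a 2.9-fold higher number from compound 2 to compound 4 (0.46 log units; beyond the scatter) between the 2,3-dimethylphenyl and 2,4-dimethylphenyl groups. The presence of two methyl groups alone therefore does not match the result of compound 2, and the step of a 1.3-fold lower number from compound 1 to compound 4 (0.12 log units; within the scatter) leaves compound 4 and compound 1 indistinguishable despite their different substituents.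

No measurement given here accounts for any of these differences. On these data alone, it remains open whether the loss of a number in compound 3 belongs to the acetyl group itself or to the absence of a second substituent on the phenyl ring, which a 4-methylphenyl, 4-methoxyphenyl or 4-aminophenyl group on the same nitrogen could begin to separate.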